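A few compounds are considered here, and "the series" means these few. Any claim that something is new, unique, unknown or untested is made for them only; others in the source may bear on it.

Measured compounds:
Compound 1, `COc1cc(N)c(Cl)cc1NC(=O)C1CCN(C/C=C/c2ccccc2)CC1`: in a functional assay on the whole organism for antagonist activity, with Mus musculus as the target (on this read-out higher numbers stand for an effect only at larger amounts of compound and lower numbers for an effect already at smaller amounts), compound 1 gives > 10 mg/kg, which is a limit of the assay and not a number.
Compound 2, `CCCN1CCC(C(=O)Nc2cc(Cl)c(N)cc2OC)CC1`: in this assay compound 2 gives > 10 mg/kg, also a limit rather than a number.
Compound 3, `COc1cc(N)c(Cl)cc1NC(=O)C1CCN(Cc2cccc(C#N)c2)CC1`: in this assay compound 3 gives > 4 mg/kg, again only a limit.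

Compound 3 therefore stands at a limit, and the two other values are limits as well: the limit of > 10 mg/kg in this assay, at which 2 of the 3 values shown sit, and (the limit of > 4 mg/kg in this assay, at which 1 of the 3 values shown sits). Compound 4, `COc1cc(N)c(Cl)cc1NC(=O)C1CCN(CC2CCCC2)CC1`, has not been measured yet. It differs from compound 3 in one place: cyclopentyl in place of 3-cyanophenyl on a saturated chain carbon bound to an amine nitrogen in a ring. Three measured steps change this same position, but none of them can be read, since each runs between two limits: a step that the two limits leave unreadable from compound 1 to compound 2, a step that the two limits leave unreadable from compound 1 to compound 3 and a step that the two limits leave unreadable from compound 2 to compound 3. No size in either direction can be drawn from them, so no step beyond the scatter is expected; what is expected is a step that the limit leaves unreadable from compound 3 to compound 4. For compound 4 the estimated value in this assay is 10 mg/kg, with a range from 2 mg/kg to 40 mg/kg, and a further limit instead of a number is considered likely.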

Compound 4, dose for half-maximal effect: > 10 mg/kg
Compound 4 ended at the assay's limit (the forecaster's own chance of this, stated with the estimate: 60%); the middle value sits exactly at the limit.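

In this assay compound 4 gives > 10 mg/kg, a limit and not a number, so its steps from compound 1, compound 2 and compound 3 cannot be read. The compounds shown leave open what dose any of them needs for half-maximal effect, and whether changing this group shifts that dose.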